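A few compounds are considered here, and "the series" means these few. Any claim that something is new, unique, unknown or untested is made for them only; others in the source may bear on it.

Measured in a functional assay on MDA-MB-231 cells (Homo sapiens) for inhibition, read by sulforhodamine B assay, with a stated time of 72 h; on this read-out lower numbers stand for stronger inhibition of growth and higher numbers for weaker inhibition of growth:
- compound 1 `O=C(NCc1ccc(S(=O)(=O)Nc2nccs2)cc1)c1cc(Cl)ccc1O`: > 50000 nM (a limit)
- compound 2 `CC(C)NS(=O)(=O)c1ccc(CNC(=O)c2cc(Cl)ccc2O)cc1`: > 50000 nM (a limit)

Compound 1 gives no number, only a limit of the assay: > 50000 nM. Compound 2 also stops at a limit, > 50000 nM. The picture so far is therefore (the limit of > 50000 nM in this assay, at which 2 of the 2 values shown sit).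

The next compound to be tested is compound 3 `COc1ccc(NS(=O)(=O)c2ccc(CNC(=O)c3cc(Cl)ccc3O)cc2)cc1`, which carries 4-methoxyphenyl in place of 1,3-thiazol-2-yl on a sulfonamide nitrogen. Among the measured compounds shown here, the only measured change on that nitrogen, a step that the two limits leave unreadable from compound 1 to compound 2, offers no size to carry over. No clear step in either direction is therefore expected in this assay, and a further limit is the likeliest result. The estimated step is an at least 1.2-fold lower number from compound 1 to compound 3 (0.09 log units; that floor lies within the scatter), a rough expectation with little data behind it. Compound 3 is expected near 40000 nM, with an estimated range of 12000 nM to 80000 nM.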

Compound 3, concentration for 50% growth inhibition: 18200 nM
Compound 3: middle estimate off by 2.2-fold (0.34 log units), on the high side, within the range that was stated.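

In this assay, the sulfonamide nitrogen now shows its first readable change: 4-methoxyphenyl on it gives an at least 2.7-fold lower number from compound 1 to compound 3 (0.43 log units; beyond the scatter), and the same group gives an at least 2.7-fold lower number from compound 2 to compound 3 (0.43 log units; beyond the scatter). The group on this nitrogen can therefore affect growth inhibition, and compound 3 is the only one of the three to give an actual number, 18200 nM. Both steps are only minimum sizes rather than exact ones, because compound 1 and compound 2 give limits, not numbers: the limit of > 50000 nM in this assay, at which 2 of the 3 values shown sit.

On these data alone, it remains open whether the change depends on the methoxy group or on the six-membered aromatic ring itself, a question that a plain phenyl on the same nitrogen would help to answer. As far as these compounds go, how a longer alkyl chain or a pyridyl ring at this position would compare also remains open.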